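The source may hold more compounds than are shown below. What is called first, only, known or untested is meant among the compounds shown, and "the series" means these compounds.

Series measured in a functional assay on CCRF-CEM cells (Homo sapiens), with a stated time of 72 h; a higher number here means a weaker inhibitor, a lower number a stronger inhibitor:

compound 1 `O=C1Nc2ccc(Cl)cc2/C1=N/NC(=S)Nc1ccc(Cl)cc1`: 61000 nM
compound 2 `Cc1ccc(NC(=S)N/N=C2\C(=O)Nc3ccc(F)cc32)cc1`: 4800 nM
compound 3 `O=C1Nc2ccc(F)cc2/C1=N/NC(=S)Nc1ccc(Cl)cc1`: 25000 nM

Compound 3 holds the second highest number of the three: in this assay it sits a 2.4-fold lower number from compound 1 to compound 3 (0.39 log units; beyond the scatter) and a 5.2-fold higher number from compound 2 to compound 3 (0.72 log units; beyond the scatter). Both measured steps concern substituents on aromatic carbons, one on the shared core and one on the outer ring, and both are modest.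

Compound 4 `O=C1/C(=N\NC(=S)Nc2ccc(Cl)cc2)c2cc(F)ccc2N1Cc1ccc(F)cc1` differs from compound 3 by 4-fluorobenzyl in place of hydrogen on an amide-type nitrogen in a ring. Within the data shown here, no measured step touches this nitrogen, so neither of the two known steps bears directly on the change; the series gives no direct guide, and the step is a larger structural change than either of the measured ones. The working expectation in this assay is therefore a step of uncertain direction, most likely within or only modestly beyond the scatter, written here as a 1.7-fold lower number from compound 3 to compound 4 (0.22 log units; within the scatter). On that basis compound 4 is estimated at 15000 nM, with a range from 4000 nM to 60000 nM.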

Compound 4, half-maximal inhibitory concentration: 56000 nM
Compound 4: the middle estimate sits 3.7-fold (0.57 log units) below what was measured, within the range that was stated.
By their numbers in this assay, from the lowest: compound 2; then compound 3; then compounds 4 and 1 (each within the scatter of the next).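

Working from this assay, 4-fluorobenzyl in place of hydrogen on the amide-type nitrogen in the ring gives a 2.2-fold higher number from compound 3 to compound 4 (0.35 log units; beyond the scatter). This is the first read on this nitrogen: the series had so far shown only changes to substituents on aromatic carbons, and this much larger group costs only a modest step, so the position tolerates substitution without loss of a measurable number. No data on hand explain the direction or size of this step.

Open, as far as these compounds go, is whether the step follows from losing the amide hydrogen or from the 4-fluorobenzyl group itself, which a small group such as methyl, an unsubstituted benzyl or a chain ending in a carboxylic acid at this nitrogen could separate. Also open, from the compounds shown here alone, is whether the step would hold with the outer ring of compound 2 or the core of compound 1.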